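Moving the bromine on compound 3

The source may report more compounds than this note shows. Statements on the series, on what has been measured and on what is new or still open speak of the compounds shown alone.

compound 1 `O=C(CN1CCN(C(=O)c2ccc(Br)cc2)CC1)N1CCN(CCCc2c[nH]c3ccccc23)CC1`: 59300 nM
compound 2 `O=C(CN1CCN(C(=O)c2ccc(Br)cc2)CC1)N1CCN(CCCc2c[nH]c3ccc(F)cc23)CC1`: 47400 nM
compound 3 `COc1ccc2[nH]cc(CCCN3CCN(C(=O)CN4CCN(C(=O)c5ccc(Br)cc5)CC4)CC3)c2c1`: 150000 nM

These values come from an ADME assay on SH-SY5Y cells (Homo sapiens) for cytotoxicity, read by MTT assay, with a stated time of 72 h; on this read-out lower numbers stand for stronger inhibition and higher numbers for weaker inhibition. Compound 3 gives the highest number of the three, 150000 nM, so it is the weakest inhibitor so far. The next compound, compound 4 `COc1ccc2[nH]cc(CCCN3CCN(C(=O)CN4CCN(C(=O)c5ccccc5Br)CC4)CC3)c2c1`, has the same atoms joined differently: 2-bromophenyl in place of 4-bromophenyl on a carbonyl carbon. In short, 2-bromophenyl stands in place of 4-bromophenyl on a carbonyl carbon.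

Within the data shown here, no measured step makes this change. The three steps swap hydrogen, fluoro or methoxy on an aromatic carbon, so they offer only a rough guide to size. The first is a 1.3-fold lower number from compound 1 to compound 2 (0.10 log units; within the scatter). The two others are modest: a 2.5-fold higher number from compound 1 to compound 3 (0.40 log units; beyond the scatter) and a 3.2-fold higher number from compound 2 to compound 3 (0.50 log units; beyond the scatter). The direction for compound 4 therefore cannot be read from the data, and no change beyond the scatter is expected in this assay, with only a slight lean downward from the top value. The expected change is a 1.4-fold lower number from compound 3 to compound 4 (0.13 log units; within the scatter). For compound 4 the estimated value is 110000 nM, with an expected range of 50000 nM to 230000 nM.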

Compound 4, half-maximal inhibitory concentration: 111000 nM
Compound 4: middle estimate off by 1.0-fold (0.00 log units), on the low side, and the stated range covers the measured number.
By their numbers in this assay, from the lowest: compounds 2, 1, 4 and 3 (each within the scatter of the next, the first and the last beyond it).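

In this assay, replacing 4-bromophenyl with 2-bromophenyl on the carbonyl carbon gives a 1.4-fold lower number from compound 3 to compound 4 (0.13 log units; within the scatter), so the two placements of the bromine cannot be told apart in this measurement. The earlier steps exchanged only hydrogen, fluoro or methoxy on an aromatic carbon and kept the 4-bromophenyl unchanged, so this is the first change shown in the bromophenyl group itself. No measurement offers an explanation for this result.

On these data alone, it remains open whether a carboxylic acid or an amine in place of the bromine would shift the number beyond the scatter. It is also unknown whether the same swap of 4-bromophenyl for 2-bromophenyl would give a similar result on compound 1 or compound 2.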